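The source may report more compounds than this note shows. Statements on the series, on what has been measured and on what is new or still open speak of the compounds shown alone.

Compound 1 `COc1cccc(CNCCCNc2ccnc3cc(-c4ccc(C(C)(C)C)cc4)ccc23)c1O` is measured in a physicochemical assay for solubility, with a stated time of 18 h, at pH 7.4 (on this read-out lower numbers stand for lower solubility and higher numbers for higher solubility), where compound 1 gives 32000 nM. Compound 2 `CC(C)(C)c1ccc(-c2ccc3c(NCCCNCc4ccco4)ccnc3c2)cc1` gives 32000 nM, and the step of no change at the digits printed from compound 1 to compound 2 (within the scatter) shows the two stand level, together the highest of the three numbers. Compound 3 `COc1ccc(F)cc1CNCCCNc1ccnc2cc(Oc3ccc(C(C)(C)C)cc3)ccc12` gives 14500 nM, a lower number than compound 1 that lies beyond the scatter. Compound 4 `COc1ccccc1Oc1ccc2c(NCCCNCc3cccc(OC)c3O)ccnc2c1` is not yet measured; it differs from compound 1 in one place: 2-methoxyphenoxy in place of 4-(tert-butyl)phenyl on an aromatic carbon. Among the compounds with values here, none of the measured steps touches this part of the molecule, and compound 3 differs from compound 1 in more than one place, so no step gives a direct guide. With nothing pointing either way, little change beyond the scatter is expected, as the step of a 1.3-fold higher number from compound 1 to compound 4 (0.10 log units; within the scatter). Compound 4 is therefore estimated at 40000 nM, between 18000 nM and 90000 nM.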

Compound 4, solubility: 14500 nM
For compound 4 the middle estimate is 2.8-fold (0.44 log units) above the measured one; measured number below the stated range.
By their numbers in this assay, from the lowest: compounds 3 and 4 (each within the scatter of the next); then compounds 1 and 2 (each within the scatter of the next).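

In this assay, placing 2-methoxyphenoxy instead of 4-(tert-butyl)phenyl on this aromatic carbon gives a 2.2-fold lower number from compound 1 to compound 4 (0.34 log units; beyond the scatter), so this position can move the read-out, though only modestly. The entering group brings two hydrogen-bond acceptors and the leaving group none, but this single pair cannot tie the drop to that difference. No supporting measurement explains the drop.

On these data alone, the ether oxygen and the methoxy group enter together, so their separate contributions remain open. Plain phenoxy, or an amine such as morpholine, at this position would be a further test of how this position responds.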